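A few compounds are considered here, and "the series" means these few. Any claim that something is new, unique, unknown or untested is made for them only; others in the source may bear on it.

For the measured compounds named here, in a functional assay on SMMC-7721 cells (Homo sapiens) for cytotoxicity, read by MTT assay, with a stated time of 24 h (on this read-out higher numbers stand for weaker inhibition and lower numbers for stronger inhibition), compound 1 (`COc1cc(/C=C2\CN(S(=O)(=O)c3ccc(F)cc3)C/C(=C\c3ccccc3F)C2=O)cc(OC)c1`) gives 6890 nM and compound 2 (`COc1cc(/C=C2\CN(S(=O)(=O)c3ccc(F)cc3)C/C(=C\c3ccc(C#N)cc3)C2=O)cc(OC)c1OC`) gives 4120 nM as its value, so compound 2 stands within the scatter of compound 1 on the numbers so far. Going by the values given here, the two compounds differ in more than one place, and no measured pair isolates a single change.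

Compound 3 (`COc1cc(/C=C2\CN(S(=O)(=O)c3ccc(F)cc3)C/C(=C\c3cc(OC)c(OC)c(OC)c3)C2=O)cc(OC)c1`) is still to be measured in this assay and differs from compound 2 as follows: 3,5-dimethoxyphenyl in place of 4-cyanophenyl on a double-bonded chain carbon bound to a double-bonded ring carbon.

Among the compounds with values here, no measured step speaks to this exchange, so the data give no direct guide to its size or direction. With compound 1 at 6890 nM and compound 2 at 4120 nM as the only reference points, no step beyond the scatter is expected. The expected step is a 1.2-fold higher number from compound 2 to compound 3 (0.08 log units; within the scatter) and remains an estimate within the scatter. For compound 3 the estimated value is 5000 nM with an expected range of 2000 nM to 12000 nM across repeat measurements.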

Compound 3, half-maximal inhibitory concentration: 5420 nM
Beside the measured number, compound 3's estimate is 1.1-fold (0.04 log units) below it; low and high end bracket the measured number.
By their numbers in this assay, from the lowest: compounds 2, 3 and 1 (each within the scatter of the next).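

In this assay, for the compounds shown here, the exchange of 4-cyanophenyl for 3,5-dimethoxyphenyl on a double-bonded chain carbon bound to a double-bonded ring carbon gives a 1.3-fold higher number from compound 2 to compound 3 (0.12 log units; within the scatter) and stays within the scatter, the first single-place reading at this kind of position. Going by these compounds alone, the exchange of 2-fluorophenyl for 3,4,5-trimethoxyphenyl at the same kind of place gives a 1.3-fold lower number from compound 1 to compound 3 (0.10 log units; within the scatter) and also stays within the scatter, so neither exchange separates its pair and, across these three compounds, the groups tried here give no step that can be told from repeat measurements. The data at hand offer no explanation for how little these exchanges register.

On these data alone, whether any group at this place can move the number beyond the scatter remains open, for instance a phenyl carrying a dimethylamino group or a carboxylic acid, or a longer chain in place of the aromatic ring. Also open, as far as these compounds go, is whether the same exchanges stay this small on other cell lines, or when the rest of the shared core is changed.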